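Series notes: amine tail variation on the shared core

The source may hold more compounds than are shown below. What is called first, only, known or untested is meant among the compounds shown, and "the series" means these compounds.

Measured so far:
- compound 1, `Cn1nc2c(=O)n(CC3(O)CCN(Cc4ccc(-c5ccco5)cc4Cl)CC3)cnc2c1-c1ccc(C2(N)CC2)cc1`: 66.1 nM
- compound 2, `Cn1cc(-c2ccc(CN3CCC(O)(Cn4cnc5c(-c6ccc(CN)cc6)n(C)nc5c4=O)CC3)c(Cl)c2)cn1`: 291 nM

In an assay on isolated protein for inhibition of ubiquitin carboxyl-terminal hydrolase 7 (Homo sapiens), with stated times of 30 min and 2 h (a higher number here means a weaker inhibitor, a lower number a stronger inhibitor), compound 1 gives 66.1 nM, the lower of the two numbers recorded so far. Compound 2 gives 291 nM, a higher number, and the gap between the two lies beyond the usual scatter; as compound 2 differs from compound 1 in more than one place, no single change can be read from that gap.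

The step under review leads from compound 1 to compound 3, `CN(C)Cc1ccc(-c2c3ncn(CC4(O)CCN(Cc5ccc(-c6ccco6)cc5Cl)CC4)c(=O)c3nn2C)cc1`. Among the compounds with values here, the only change is (dimethylamino)methyl in place of 1-aminocyclopropyl on an aromatic carbon. Within the data shown here, both groups keep a basic nitrogen, and no measured pair in this set isolates a change of this kind, so the size and direction of the step cannot be anchored on data. The expectation is a step of modest size, if any, with the number for compound 3 somewhat higher than that of compound 1 but possibly within scatter.

Compound 3 is therefore expected to give about 100 nM in this assay, with a range from 35 nM to 300 nM. The corresponding estimated step is a 1.5-fold higher number from compound 1 to compound 3 (0.18 log units; within the scatter).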

Compound 3, half-maximal inhibitory concentration: 131 nM
The estimate for compound 3 lay 1.3-fold (0.12 log units) below the measured number; low and high end bracket the measured number.
By their numbers in this assay, from the lowest: compounds 1 and 3 (each within the scatter of the next); then compound 2.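

In this assay, within the data shown here, (dimethylamino)methyl in place of 1-aminocyclopropyl, on an aromatic carbon para to a large group, gives a 2.0-fold higher number from compound 1 to compound 3 (0.30 log units; within the scatter), the first reading of a single change. The entering group has no ring and no hydrogen-bond donor, yet with the same heavy-atom count and the rest of compound 1 unchanged, this step does not separate the two groups, so neither the three-membered ring nor the donor on the leaving group is shown to be needed in this assay for these two compounds. No measurement on hand connects this step to any property of either group.

The steps from compound 2 to compound 1 and to compound 3 cannot be read, as compound 2 differs from each in more than one place, so the aminomethyl group it carries at this position says nothing yet about this position on its own. Still open, as far as these compounds go, is how far this position tolerates change with the rest of compound 1 held fixed, for example with 1-(dimethylamino)cyclopropyl, which keeps the ring and the methyl groups together, or with a carboxylic acid, which has no amine.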